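The source may hold more compounds than are shown below. What is called first, only, known or untested is meant among the compounds shown, and "the series" means these compounds.

So far two compounds have numbers in an ADME assay (Rattus norvegicus, strain Han-wistar) for pharmacokinetics, at a dose of 1.5 umol/kg by the intravenous route; a lower number here means slower removal, a higher number faster removal of the compound. Compound 1 (`CNC(=O)CN1CCC(c2cc3c(-c4ccc(=O)n(C(C)C)c4)ccnc3[nH]2)CC1`) gives 89 mL/min/kg, and compound 2 (`COc1cc(F)ccc1-c1ccnc2[nH]c(C3CCN(CC(=O)N(C)C)CC3)cc12`) gives 51 mL/min/kg. These two values lie within the usual scatter of repeated measurements, so compound 2 cannot be told apart from compound 1 on this read-out.

Compound 3 (`CC(C)n1nc(-c2ccnc3[nH]c(C4CCN(CC(=O)N(C)C)CC4)cc23)ccc1=O`) has not yet been measured. It arises from compound 2 by exchanging the 4-fluoro-2-methoxyphenyl group, on an aromatic carbon of the shared core, for a group with a six-membered aromatic ring with 2 hetero atoms: a group of 10 heavy atoms (7 carbon, 2 nitrogen, 1 oxygen; one six-membered aromatic ring with 2 hetero atoms) in place of a group of 9 heavy atoms (7 carbon, 1 oxygen, 1 fluorine; one six-membered aromatic ring of carbon only), on an aromatic carbon.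

Going by the values given here, no measured pair shows what this exchange does, so the two values above are the only guide. A small upward move that stays within the scatter is expected, and the estimated step is a 1.2-fold higher number from compound 2 to compound 3 (0.07 log units; within the scatter). For compound 3 the estimated clearance is 60 mL/min/kg, with an expected range of 35 mL/min/kg to 100 mL/min/kg.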

Compound 3, clearance: 72 mL/min/kg
Compound 3: the middle estimate sits 1.2-fold (0.08 log units) below what was measured; the measured number falls inside the stated range.
By their numbers in this assay, from the lowest: compounds 2, 3 and 1 (each within the scatter of the next).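

Going by these compounds alone, this is the first comparison in which only one place changes. On the aromatic carbon opposite the ring nitrogen, a six-membered aromatic ring with 2 hetero atoms replaces the 4-fluoro-2-methoxyphenyl group, and this assay shows a 1.4-fold higher number from compound 2 to compound 3 (0.15 log units; within the scatter) for this exchange. So replacing the whole group, including a change in ring atoms and in the number of hydrogen-bond acceptors, does not clearly separate the two compounds on this read-out. No supporting measurement bears on this result. As far as these compounds go, only these two groups can be compared at this aromatic carbon, so it stays open whether any group placed there moves clearance beyond the scatter. A much smaller group such as a methyl, an amine or a carboxylic acid on the same carbon would test this.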